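This account rests on a few compounds, and the source may have more. Where it says the series, first, only, none or still open, it means among the compounds named here.

Measured compounds in a functional assay on BXPC-3 cells (Homo sapiens) for inhibition, read by MTT assay, with a stated time of 7 days; on this read-out higher numbers stand for weaker inhibition and lower numbers for stronger inhibition:
- compound 1, `CCN(CC)S(=O)(=O)c1ccc(S(=O)(=O)N2CCC[C@@H](C(=O)N3CCC(O)CC3)C2)cc1`: 4710 nM
- compound 2, `CCN(CC)S(=O)(=O)c1ccc(S(=O)(=O)N2CCC[C@@H](C(=O)N[C@H]3CC[C@@H](OC)CC3)C2)cc1`: 2150 nM
- compound 3, `CCN(CC)S(=O)(=O)c1ccc(S(=O)(=O)N2CCC[C@@H](C(=O)N3CCC(COC)CC3)C2)cc1`: 1360 nM

Compound 3 holds the lowest of the three numbers in this assay, but its distance from compound 2 is a 1.6-fold lower number from compound 2 to compound 3 (0.20 log units; within the scatter), which is within the scatter; only the gap to compound 1, a 3.5-fold lower number from compound 1 to compound 3 (0.54 log units; beyond the scatter), is beyond it. The step of a 2.2-fold lower number from compound 1 to compound 2 (0.34 log units; beyond the scatter) is also beyond the scatter, so both changes away from compound 1 moved the number down by modest amounts.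

Compound 4, `CCN(CC)S(=O)(=O)c1ccc(S(=O)(=O)N2CCC[C@@H](C(=O)N[C@H]3CCOC3)C2)cc1`, differs from compound 3 as follows: (oxolan-3-yl)amino in place of 4-(methoxymethyl)piperidin-1-yl on a carbonyl carbon. Two earlier steps bear on this. The exchange of a piperidinyl amide for an amino amide, a 1.6-fold lower number from compound 2 to compound 3 (0.20 log units; within the scatter), changed little. The exchange of hydroxy for methoxymethyl, a 3.5-fold lower number from compound 1 to compound 3 (0.54 log units; beyond the scatter), was modest. Among the compounds with values here, compound 4 keeps an ether oxygen but loses the methoxymethyl and takes the amino pattern of compound 2, so no large step in this assay is expected; a shift of roughly a 1.8-fold higher number from compound 3 to compound 4 (0.25 log units; within the scatter) toward the number of compound 2 is estimated, with a sizeable chance of no change beyond the scatter. The estimated value for compound 4 is 2400 nM, within a range of 1000 nM to 6000 nM.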

Compound 4, half-maximal inhibitory concentration: 5270 nM
Beside the measured number, compound 4's estimate is 2.2-fold (0.34 log units) below it; measured number inside the range.
By their numbers in this assay, from the lowest: compounds 3 and 2 (each within the scatter of the next); then compounds 1 and 4 (each within the scatter of the next).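

In this assay the group on this carbonyl carbon now shows that an ether oxygen alone does not hold the number down: a 3.9-fold higher number from compound 3 to compound 4 (0.59 log units; beyond the scatter) and a 2.5-fold higher number from compound 2 to compound 4 (0.39 log units; beyond the scatter) are both beyond the scatter, even though oxolan-3-yl keeps an ether oxygen, as 4-(methoxymethyl)piperidin-1-yl and 4-methoxycyclohexyl do. With a 1.1-fold higher number from compound 1 to compound 4 (0.05 log units; within the scatter) the (oxolan-3-yl)amino amide cannot be told apart from the 4-hydroxypiperidin-1-yl amide, and the amide hydrogen does not sort the set, since compound 2 and compound 4, which carry it, fall on opposite sides of the gap, as do compound 3 and compound 1, which lack it. No measurement at hand accounts for these steps.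

Still open, on these data alone, is whether the ring size or the ether's placement on the ring goes with the higher number of compound 4, a question that a 4-methoxypiperidin-1-yl amide or an open-chain 2-methoxyethyl amide would bear on. Also open, as far as these compounds go, are the other stereocentre arrangement of the oxolan-3-yl amide and how an amine or a carboxylic acid at this place would read in this assay.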